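This account rests on a few compounds, and the source may have more. Where it says the series, first, only, none or still open, it means among the compounds named here.

Measured so far in a functional assay on a cell-free system (Platelet, plasma, Oryctolagus cuniculus) for inhibition, with a stated time of 5 min, at 37 degrees C; on this read-out lower numbers stand for stronger inhibition and higher numbers for weaker inhibition:
- compound 1 `Cc1nc(C)c(C(=O)Oc2ccccc2/C=C/C(=O)O)nc1C` gives 9600 nM
- compound 2 `COc1ccc(/C=C/C(=O)O)c(OC(=O)c2nc(C)c(C)nc2C)c1` gives 134000 nM
- compound 3 `CCOC(=O)/C=C/c1ccc(OC(=O)c2nc(C)c(C)nc2C)c(OC)c1` gives 58400 nM

Compound 2 and compound 1 differ in one place, (hydrogen in place of methoxy on an aromatic carbon), and in this assay this change gives a 14-fold lower number from compound 2 to compound 1 (1.14 log units; beyond the scatter). The difference between the cores of compound 2 and compound 3 is not broken down here; compound 3 gives the second highest number of the three, nearest to compound 2 and furthest from compound 1.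

Compound 4 `CCOC(=O)/C=C/c1ccc(OC(=O)c2nc(C)c(C)nc2C)cc1` has not yet been measured in this assay. It differs from compound 3 by hydrogen in place of methoxy on an aromatic carbon. This is the same kind of change as from compound 2 to compound 1, but not the same: in compound 3 the methoxy sits ortho to a large group and meta to a 2-(ethoxycarbonyl)ethenyl group, whereas in compound 2 it sits meta to a large group and para to a 2-carboxyethenyl group. Beside a 14-fold lower number from compound 2 to compound 1 (1.14 log units; beyond the scatter), a smaller step is expected from compound 3 to compound 4, a 3.9-fold lower number from compound 3 to compound 4 (0.59 log units; beyond the scatter), resting on that single comparison discounted for the different surroundings of the place. Compound 4 is estimated at 15000 nM in this assay, with a likely range from 4000 nM to 60000 nM.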

Compound 4, half-maximal inhibitory concentration: 24400 nM
For compound 4 the middle estimate is 1.6-fold (0.21 log units) below the measured one, and the stated range covers the measured number.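

In this assay, hydrogen in place of methoxy again gives a lower number, with a 2.4-fold lower number from compound 3 to compound 4 (0.38 log units; beyond the scatter), so the direction of the change is the same on the two cores shown. The size of the step does not carry over from one core to the other: the same change on two cores in this assay, a 14-fold lower number (1.14 log units; beyond the scatter) from compound 2 to compound 1 and a 2.4-fold lower number (0.38 log units; beyond the scatter) from compound 3 to compound 4, 5.8-fold (0.77 log units) apart, beyond the scatter of two such steps. These two pairs do not show what sets the size of the step, since their cores differ both in the position of the methoxy and in carrying a 2-carboxyethenyl group in compound 2 but a 2-(ethoxycarbonyl)ethenyl group in compound 3, and they give no basis for predicting the step on a third core.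

Going by these compounds, it remains open whether a hydroxyl or a fluorine in the place of the methoxy would follow the same direction on these cores. On these data alone, it also remains open how the step would behave with an amide or a longer-chain ester in place of the ethyl ester.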